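The source may hold more compounds than are shown below. What is called first, only, known or untested is meant among the compounds shown, and "the series" means these compounds.

In a functional assay on A549 cells (Homo sapiens) for cytotoxicity, read by MTT assay, with a stated time of 48 h (a higher number here means a weaker inhibitor, a lower number a stronger inhibitor), compound 1 `NC(=O)CC[C@H](NS(=O)(=O)c1ccc([N+](=O)[O-])cc1)C(=O)O` gives > 500000 nM, which is a limit of the assay and not a number. Compound 2 `CCNC(=O)CC[C@H](NS(=O)(=O)c1ccc([N+](=O)[O-])cc1)C(=O)O` gives 221000 nM and compound 3 `CCCCNC(=O)CC[C@H](NS(=O)(=O)c1ccc([N+](=O)[O-])cc1)C(=O)O` gives 276000 nM, and these two numbers lie within the scatter of each other. Compound 4 `CCCCCNC(=O)CC[C@H](NS(=O)(=O)c1ccc([N+](=O)[O-])cc1)C(=O)O` differs from compound 2 by propyl in place of hydrogen on a saturated chain carbon, two bonds along the chain from an amide-type nitrogen. Putting a chain on that nitrogen gave an at least 2.2-fold lower number from compound 1 to compound 2 (0.35 log units; beyond the scatter), and also an at least 1.8-fold lower number from compound 1 to compound 3 (0.25 log units; that floor lies within the scatter). The closest guide is the lengthening of ethyl to butyl, which gave a 1.2-fold higher number from compound 2 to compound 3 (0.10 log units; within the scatter). The estimated step in this assay is therefore a 1.1-fold lower number from compound 2 to compound 4 (0.04 log units; within the scatter), expected to stay within the scatter. For compound 4 the expected value is 200000 nM, with an estimated range of 100000 nM to 400000 nM.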

Compound 4, half-maximal inhibitory concentration: 206000 nM
The estimate for compound 4 lay 1.0-fold (0.01 log units) below the measured number; low and high end bracket the measured number.
By their numbers in this assay, from the lowest: compounds 4, 2 and 3 (each within the scatter of the next). At a limit, above all of these: compound 1.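

Taking the chain on the amide-type nitrogen out to pentyl brings no readable change in this assay: the step is a 1.1-fold lower number from compound 2 to compound 4 (0.03 log units; within the scatter), and against butyl it is a 1.3-fold lower number from compound 3 to compound 4 (0.13 log units; within the scatter). Ethyl, butyl and pentyl therefore sit together, with no trend in chain length across compound 2, compound 3 and compound 4. Against compound 1, which keeps the amide hydrogen, pentyl gives an at least 2.4-fold lower number from compound 1 to compound 4 (0.38 log units; beyond the scatter), but that step starts from a limit of the assay and not a number: the limit of > 500000 nM in this assay, at which 1 of the 4 values shown sits.

Going by these compounds, it remains open whether a longer chain, or a chain ending in an amine or a carboxylic acid, would shift the number. On these data alone, how far compound 1 truly lies from the others also stays unknown.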